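This account rests on a few compounds, and the source may have more. Where it says the series, first, only, none or still open, it means among the compounds named here.

Compound 1 `COc1ccc([C@@H]2Oc3cc(OC)c(OC)c(OC)c3C(=O)[C@@H]2O)cc1OC` gives 28600 nM 
Compound 2 `COc1cc([C@@H]2Oc3cc(OC)c(OC)c(OC)c3C(=O)[C@@H]2O)cc(OC)c1OC` gives 19600 nM 

Among the compounds with values here, both values come from a functional assay on liver (Rattus norvegicus) for inhibition, with a stated time of 1 h (on this read-out higher numbers stand for an effect only at larger amounts of compound and lower numbers for an effect already at smaller amounts), and are the only measurements so far. Compound 2 therefore has just one neighbour on the scale, compound 1, and the two cannot be told apart: methoxy in place of hydrogen on an aromatic carbon gave a 1.5-fold lower number from compound 1 to compound 2 (0.16 log units; within the scatter) and left them level.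

Compound 3 `COc1cc([C@@H]2Oc3cc(OC)c(OC)c(OC)c3C(=O)[C@@H]2O)cc(OC)c1O` differs from compound 2 by hydrogen in place of methyl on an oxygen on an aromatic ring as hydrogen in place of methyl on an oxygen on an aromatic ring, that is, methoxy to hydroxy. Within the data shown here, no measured step makes this change, so the evidence is thin. Among the measured compounds shown here, the one step available is small and of another kind, so no step beyond the scatter is expected in this assay with any confidence. The estimated step is a 1.3-fold lower number from compound 2 to compound 3 (0.12 log units; within the scatter) and it remains uncertain. For compound 3 the expected value is 15000 nM with an estimated range from 4000 nM to 40000 nM (wide, given so little data).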

Compound 3, half-maximal effective concentration: 10400 nM
Compound 3: the middle estimate sits 1.4-fold (0.16 log units) above what was measured, and the stated range covers the measured number.
By their numbers in this assay, from the lowest: compounds 3, 2 and 1 (each within the scatter of the next, the first and the last beyond it).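

Swapping methoxy for hydroxy, with hydrogen in place of methyl on an oxygen on an aromatic ring, gives a 1.9-fold lower number from compound 2 to compound 3 (0.28 log units; within the scatter) in this assay. The earlier step added a methoxy group, whereas this one takes a single methyl away from an oxygen, and the two compounds still cannot be told apart, so this methyl can be lost without a change that stands clear of the scatter. No accompanying measurement offers an explanation for this result.

From the compounds shown here alone, it remains open whether a longer chain on this oxygen, such as ethoxy, or an amine in place of the hydroxy would move the number beyond the scatter. Going by these compounds, whether the same swap at the other methoxy groups on the core would also leave the number level is equally open.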